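From 3-Fluorophenyl to 2,4-Dichlorophenyl

The compounds below may be only part of what the source reports. "The series", "measured", "known", "first", "only" and "open" are said of these compounds alone.

In a functional assay on Jurkat cells (Homo sapiens) for antiproliferative activity, read by MTT assay, with a stated time of 72 h (a higher number here means a weaker inhibitor, a lower number a stronger inhibitor), compound 1 (`COc1cc(-c2ncnn2-c2cccc(F)c2)cc(OC)c1OC`) gives > 10000 nM as its result, which is a limit and not a number. Its true value is therefore unknown. In this assay compound 2 (`COc1cc(-n2ncnc2-c2ccc(C)cc2)cc(OC)c1OC`) gives 300 nM as a measured number. Compound 3 (`COc1cc(-c2ncnn2-c2ccc(Cl)cc2Cl)cc(OC)c1OC`) has not yet been measured. It carries 2,4-dichlorophenyl in place of 3-fluorophenyl on an aromatic nitrogen. For the measured compounds named here, no measured pair shows what such a swap does in this assay, so only a small change is expected, toward a stronger inhibitor if there is any change at all. The expected size of the change is an at least 1.4-fold lower number from compound 1 to compound 3 (0.15 log units; that floor lies within the scatter) and it remains uncertain. The assay may well report only a limit again. For compound 3 the estimated value is 7000 nM with an expected range from 1000 nM to 10000 nM in this measurement.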

Compound 3, half-maximal inhibitory concentration: > 10000 nM
Compound 3: only a limit was reported (the forecaster's own chance of this, stated with the estimate: 55%); middle value at least 1.4-fold (0.15 log units) away from the limit.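

For the compounds shown here, compound 1 and compound 3 both give only limits in this assay, so no step between them can be read, because neither result is a number: the limit of > 10000 nM in this assay, at which 2 of the 3 values shown sit.

The compounds shown leave open whether 2,4-dichlorophenyl in place of 3-fluorophenyl changes activity at all.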